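Hydroxy on the phenyl of compound 1

The source may hold more compounds than are shown below. What is called first, only, known or untested is meant among the compounds shown, and "the series" means these compounds.

Going by the values given here, in a functional assay on A549 cells (Homo sapiens) for cytotoxicity, read by MTT assay, with a stated time of 72 h (a higher number here means a weaker inhibitor, a lower number a stronger inhibitor), compound 1 `CC(C)=CCOc1ccc(C(=O)/C=C/c2ccccc2)c(O)c1` gives 54000 nM, the only numeric value so far. Compound 2 `C=C(C)CCOc1c(OC)cc(/C=C/CO)cc1OC` stands at > 100000 nM, which is a limit and not a number. Compound 3 `CC(C)=CCOc1ccc(C(=O)/C=C/c2ccc(O)cc2)c(O)c1` differs from compound 1 by hydroxy in place of hydrogen on an aromatic carbon, with hydroxy in place of hydrogen on an aromatic carbon, so phenyl becomes 4-hydroxyphenyl. Among the compounds with values here, no measured step bears on this change, so the estimated step of a 1.4-fold lower number from compound 1 to compound 3 (0.13 log units; within the scatter) is small, towards a stronger inhibitor, and may stay within the usual scatter. For compound 3 the expected value is 40000 nM, with an estimated range of 15000 nM to 100000 nM.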

Compound 3, half-maximal inhibitory concentration: 66000 nM
The estimate for compound 3 lay 1.7-fold (0.22 log units) below the measured number; low and high end bracket the measured number.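

In this assay, going by these compounds alone, the first step with two numbers on the shared core is a 1.2-fold higher number from compound 1 to compound 3 (0.09 log units; within the scatter), so turning phenyl into 4-hydroxyphenyl leaves the read-out unresolved from compound 1. This position accepts hydroxy without a readable gain or loss, though this is a single step on a single core. Compound 2 marks the top of the readable range: the limit of > 100000 nM in this assay, at which 1 of the 3 values shown sits.

From the compounds shown here alone, whether the same carbon stays this flat with an amine, a carboxylic acid or a longer chain remains open. Hydroxy at the other carbons of this phenyl also remains open.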